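The source may hold more compounds than are shown below. What is called first, only, known or untested is meant among the compounds shown, and "the series" means these compounds.

Measured compounds:
Compound 1 `COc1ccc(-c2cc3ccccc3nc2/C=C/C(=O)c2ccccc2)cc1` gives 700 nM in a functional assay on SK-BR-3 cells (Homo sapiens) for antiproliferative activity, read by XTT assay, with a stated time of 72 h; on this read-out lower numbers stand for stronger inhibition and higher numbers for weaker inhibition.
Compound 2 `COc1ccc(-c2cc3ccccc3nc2/C=C/C(=O)c2ccc(OC)cc2OC)cc1` gives 2260 nM in this assay.
Compound 3 `COc1ccc(-c2cc3ccccc3nc2/C=C/C(=O)c2ccc(OC)c(OC)c2)cc1` gives 3260 nM in this assay.

Among the three measured compounds, compound 3 carries the highest number in this assay. Compound 2 stands nearest to it, and the difference a 1.4-fold higher number from compound 2 to compound 3 (0.16 log units; within the scatter) is within the scatter, so the two cannot be ordered. Compound 1 stands furthest away, with a 4.7-fold higher number from compound 1 to compound 3 (0.67 log units; beyond the scatter) marking a step beyond the scatter.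

Compound 4 `COc1ccc(-c2cc3ccccc3nc2/C=C/C(=O)c2ccc([N+](=O)[O-])cc2)cc1` differs from compound 3 in one place: 4-nitrophenyl in place of 3,4-dimethoxyphenyl on a carbonyl carbon. Among the measured compounds shown here, two measured steps bear on this position. Going from the unsubstituted phenyl of compound 1 to the dimethoxy-bearing rings gave a 3.2-fold higher number from compound 1 to compound 2 (0.51 log units; beyond the scatter) and a 4.7-fold higher number from compound 1 to compound 3 (0.67 log units; beyond the scatter), both modest steps towards weaker inhibition. For the measured compounds named here, no measured compound carries a nitro group, so the effect of the entering group itself is untested. Because compound 1 with plain phenyl gives 700 nM, the removal of the two methoxy groups is expected to bring a modest step downward, a 2.2-fold lower number from compound 3 to compound 4 (0.34 log units; beyond the scatter), while the untested nitro group leaves the range wide. Compound 4 is therefore estimated at 1500 nM, expected to fall between 400 nM and 6000 nM.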

Compound 4, half-maximal inhibitory concentration: 590 nM
The estimate for compound 4 lay 2.5-fold (0.41 log units) above the measured number; measured number inside the range.
By their numbers in this assay, from the lowest: compounds 4 and 1 (each within the scatter of the next); then compounds 2 and 3 (each within the scatter of the next).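

In this assay the 4-nitrophenyl ring does not share the weaker inhibition seen with the dimethoxy-bearing rings, with a 5.5-fold lower number from compound 3 to compound 4 (0.74 log units; beyond the scatter) and a 3.8-fold lower number from compound 2 to compound 4 (0.58 log units; beyond the scatter) both lying beyond the scatter. Nitro in place of hydrogen on the plain phenyl makes no readable difference, at a 1.2-fold lower number from compound 1 to compound 4 (0.07 log units; within the scatter) within the scatter, so among these four compounds a substituted ring on the carbonyl carbon need not cost activity, and only the two dimethoxyphenyl rings, in compounds 2 and 3, give higher numbers. Nothing at hand explains why the nitro and methoxy groups differ here.

Going by these compounds, it remains open whether one methoxy group on this ring would already raise the number. On these data alone, it is equally open whether an amine or a carboxylic acid in place of the nitro group would stay level with compound 4.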